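The source may hold more compounds than are shown below. What is called first, only, known or untested is meant among the compounds shown, and "the series" means these compounds.

Of the compounds shown here, three sharing one core have been measured in an assay on CHO cells for displacement of a labelled ligand from adenosine receptor A3 (Homo sapiens), read by scintillation counting, tested at 1 uM; a higher number here means more inhibition at the concentration tested (going by the name of the read-out), a lower number less inhibition. Compound 1 `CCc1nc(N)c2nn(-c3ccccc3)cc2n1` gives 38%, compound 2 `CC(C)Cc1nc(N)c2nn(-c3ccccc3)cc2n1` gives 13%, and compound 3 `Cc1cccc(Cc2nc(N)c3nn(-c4ccccc4)cc3n2)c1` gives 11%. Compound 2 thus stands second highest of the three, close to compound 3 and well below compound 1, as the change a number 25 percentage points lower from compound 1 to compound 2 (beyond the scatter) shows.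

Compound 4 `Cc1ccc(Cc2nc(N)c3nn(-c4ccccc4)cc3n2)cc1` has not been measured yet. It differs from compound 2 in one place: 4-methylphenyl in place of isopropyl on a saturated chain carbon bound to an aromatic carbon. The closest measured step is a number 2 percentage points lower from compound 2 to compound 3 (within the scatter), where a related methylphenyl group entered at the same place without moving the number beyond the scatter. From that, no change beyond the scatter is expected here, so a number 1 percentage points lower from compound 2 to compound 4 (within the scatter) is the expected step, giving compound 4 an estimate of 12%, with a range from 0% to 28%.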

Compound 4, a percentage reported as inhibition, at one concentration (the size of the read-out at that concentration, not a potency): 39%
Beside the measured number, compound 4's estimate is 27 percentage points below it; the whole stated range lies below it.
By their numbers in this assay, from the lowest: compounds 3 and 2 (each within the scatter of the next); then compounds 1 and 4 (each within the scatter of the next).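

Here 3-methylphenyl and 4-methylphenyl are not interchangeable: on the same saturated chain carbon, swapping one for the other moves the number beyond the scatter (a number 28 percentage points higher from compound 3 to compound 4 (beyond the scatter)). More heavy atoms in the group therefore do not by themselves lower the number, as 4-methylphenyl in place of isopropyl shows (a number 26 percentage points higher from compound 2 to compound 4 (beyond the scatter)), while 4-methylphenyl in place of methyl stays within the scatter (a number 1 percentage points higher from compound 1 to compound 4 (within the scatter)). No evidence shown here accounts for this difference between the two methylphenyl groups. Still open, from the compounds shown here alone, is how a plain phenyl group, or a longer chain ending in an amine, would behave at this place.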